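From Bromo to Carboxy: Estimating Compound 4

The source may report more compounds than this note shows. Statements on the series, on what has been measured and on what is new or still open speak of the compounds shown alone.

Compound 1 `O=c1cc(-c2ccccc2)oc2cc(OCCCCNc3nc4ccccc4s3)cc(O)c12` gives 4.75 ug/mL in a functional assay on HeLa cells (Homo sapiens) for cytotoxicity, read by sulforhodamine B assay, with a stated time of 48 h; a lower number here means a stronger inhibitor, a higher number a weaker inhibitor.
Compound 2 `Cc1ccc2nc(NCCCCOc3cc(O)c4c(=O)cc(-c5ccccc5)oc4c3)sc2c1` gives 6.56 ug/mL.
Compound 3 `O=c1cc(-c2ccccc2)oc2cc(OCCCCNc3nc4ccc(Br)cc4s3)cc(O)c12` gives 6.56 ug/mL.

Compound 3 sits level with compound 2 at the digits shown, the two together highest of the three; toward compound 1 the step is a 1.4-fold higher number from compound 1 to compound 3 (0.14 log units; within the scatter), and among the others a 1.4-fold higher number from compound 1 to compound 2 (0.14 log units; within the scatter) and no change at the digits printed from compound 2 to compound 3 (within the scatter). Compound 4 `O=C(O)c1ccc2nc(NCCCCOc3cc(O)c4c(=O)cc(-c5ccccc5)oc4c3)sc2c1` differs from compound 3 by carboxy in place of bromo on an aromatic carbon. Going by the values given here, no measured step exchanges a ring substituent for a carboxy group, so the three steps above, all within the scatter, are the only guide. They suggest that a change on this aromatic carbon leaves this assay largely unmoved, and compound 4 is therefore expected to show a 1.1-fold higher number from compound 3 to compound 4 (0.03 log units; within the scatter). The estimate for compound 4 is 7 ug/mL, with a range from 3 ug/mL to 16 ug/mL.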

Compound 4, half-maximal inhibitory concentration: 8.43 ug/mL
Estimate against measurement, compound 4: 1.2-fold (0.08 log units) below; the measured number falls inside the stated range.
By their numbers in this assay, from the lowest: compounds 1, 2, 3 and 4 (each within the scatter of the next).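

Going by these compounds alone, on this aromatic carbon the earlier compounds carried only hydrogen, methyl or bromo, and carboxy, which adds a hydrogen-bond donor and a hydrogen-bond acceptor, also stays within the scatter in this assay: a 1.3-fold higher number from compound 3 to compound 4 (0.11 log units; within the scatter), a 1.3-fold higher number from compound 2 to compound 4 (0.11 log units; within the scatter) and a 1.8-fold higher number from compound 1 to compound 4 (0.25 log units; within the scatter). The four groups shown at this position therefore cannot be told apart in this read-out, and nothing measured here accounts for that. From the compounds shown here alone, whether an amine on this carbon, or a longer chain in the linker, would give a step beyond the scatter remains open.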